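The compounds below may be only part of what the source reports. "The series", "measured", "known", "first", "only" and "open" are said of these compounds alone.

In a functional assay on A549 cells (Homo sapiens) for cytotoxicity, read by MTT assay, with a stated time of 72 h (a lower number here means a stronger inhibitor, a higher number a weaker inhibitor), three compounds sharing one core have been measured. Compound 1 (`CCN(CC)Cc1ccc2nc(NC(=O)N/N=C/c3cn(Cc4ccc(Cl)cc4Cl)c4ccccc34)sc2c1`) gives 1900 nM, compound 2 (`CCN(CC)Cc1ccc2nc(NC(=O)N/N=C/c3cn(Cc4cccc(Cl)c4)c4ccccc34)sc2c1`) gives 2410 nM and compound 3 (`CCN(CC)Cc1ccc2nc(NC(=O)N/N=C/c3cn(Cc4ccc(C)cc4)c4ccccc34)sc2c1`) gives 1510 nM, so compound 3 stands within the scatter of both others. Compound 4 (`CCN(CC)Cc1ccc2nc(NC(=O)N/N=C/c3cn(Cc4ccc(Cl)cc4)c4ccccc34)sc2c1`) differs from compound 3 by chloro in place of methyl on an aromatic carbon. The measured steps that bear on this change are a 1.6-fold lower number from compound 2 to compound 3 (0.20 log units; within the scatter) and a 1.3-fold lower number from compound 1 to compound 3 (0.10 log units; within the scatter), and a 1.3-fold higher number from compound 1 to compound 2 (0.10 log units; within the scatter) is also small. All three lie within the scatter, so no step beyond the scatter is expected in this assay. The expected change is a 1.1-fold higher number from compound 3 to compound 4 (0.05 log units; within the scatter). For compound 4 the estimate is 1700 nM, with an expected range of 1000 nM to 2900 nM.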

Compound 4, half-maximal inhibitory concentration: 2940 nM
Compound 4: middle estimate off by 1.7-fold (0.24 log units), on the low side; measured number outside the range, above it.
By their numbers in this assay, from the lowest: compounds 3, 1, 2 and 4 (each within the scatter of the next).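

In this assay, chloro in place of methyl on this aromatic carbon gives a 1.9-fold higher number from compound 3 to compound 4 (0.29 log units; within the scatter), and 4-chlorophenyl in place of 3-chlorophenyl gives a 1.2-fold higher number from compound 2 to compound 4 (0.09 log units; within the scatter), so neither the swap of these two groups nor the placing of the chloro takes the number beyond the scatter. Hydrogen in place of chloro on an aromatic carbon gives a 1.5-fold higher number from compound 1 to compound 4 (0.19 log units; within the scatter), which also stays within the scatter. Nothing measured on these compounds offers an explanation for these steps. From the compounds shown here alone, whether an amine, a carboxylic acid or a methoxy group on this ring would move the number beyond the scatter remains open.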